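The source may hold more compounds than are shown below. What is called first, only, known or untested is meant among the compounds shown, and "the series" means these compounds.

In a functional assay on MCF7 cells (Homo sapiens) for antiproliferative activity, with a stated time of 5 days (on this read-out higher numbers stand for weaker inhibition and lower numbers for stronger inhibition), compound 1 (`CCCCc1ccc2[nH]c(-c3ccc(OC)cc3)c(/C=N/O)c2c1`) gives 212 nM and compound 2 (`CCCCc1ccc2[nH]c(-c3ccc(OC)cc3)c(/C=N/NC(=O)c3ccc(F)cc3)c2c1`) gives 84 nM while compound 3 (`CCCCc1ccc2[nH]c(-c3ccc(OC)cc3)c(/C=N/NC(=O)c3ccc([N+](=O)[O-])cc3)c2c1`) stands at 312 nM within the scatter of compound 1 and beyond the scatter above compound 2. Compound 4 (`CCCCc1ccc2[nH]c(-c3ccc(OC)cc3)c(/C=N/NC(=O)c3ccccn3)c2c1`) carries pyridin-2-yl in place of 4-nitrophenyl on a carbonyl carbon. Two modest measured steps bear on this change (a 2.5-fold lower number from compound 1 to compound 2 (0.40 log units; beyond the scatter)) and (a 3.7-fold higher number from compound 2 to compound 3 (0.57 log units; beyond the scatter)), the second within the aromatic group that leaves here. Within the data shown here, no compound with pyridin-2-yl has been measured. Compound 2 at 84 nM gives the lower reference, so a small fall is expected. In this assay the expected move is a 1.7-fold lower number from compound 3 to compound 4 (0.24 log units; within the scatter) and it may stay within the scatter. Compound 4 is estimated at 180 nM (range 70 nM to 460 nM).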

Compound 4, half-maximal inhibitory concentration: 160 nM
For compound 4 the middle estimate is 1.1-fold (0.05 log units) above the measured one; the range from low to high includes it.
By their numbers in this assay, from the lowest: compounds 2, 4, 1 and 3 (each within the scatter of the next, the first and the last beyond it).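

On a carbonyl carbon whose other neighbour is an amide-type nitrogen, pyridin-2-yl places a ring with a hetero atom in this position, and this assay does not separate it from 4-nitrophenyl (a 2.0-fold lower number from compound 3 to compound 4 (0.29 log units; within the scatter)) or from 4-fluorophenyl (a 1.9-fold higher number from compound 2 to compound 4 (0.28 log units; within the scatter)). On the double-bonded nitrogen, ((pyridin-2-yl)carbonyl)amino is likewise not separated from hydroxy (a 1.3-fold lower number from compound 1 to compound 4 (0.12 log units; within the scatter)). Nothing measured here offers a cause for these readings. Open, on these data alone, is how a carbonyl group carrying an aminophenyl or carboxyphenyl group would read, and whether piperidin-1-yl on that carbonyl carbon would stand apart from pyridin-2-yl.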